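Enlarging the Group on the Aromatic Nitrogen

This account rests on a few compounds, and the source may have more. Where it says the series, first, only, none or still open, it means among the compounds named here.

Compound 1 `Cc1ccc(C(=O)Nc2cccc(C(F)(F)F)c2)cc1-c1ccc2c(-c3cnn(C)c3)n[nH]c2c1` was tested in a functional assay on KG-1 cells (Homo sapiens) for antiproliferative activity, read by CCK-8 assay, with a stated time of 72 h (on this read-out lower numbers stand for stronger inhibition and higher numbers for weaker inhibition), where compound 1 gives 65.7 nM, the lowest number among the three measured compounds. Compound 3 `Cc1ccc(C(=O)Nc2cccc(C(F)(F)F)c2)cc1-c1ccc2c(-c3cnn(C4CCCCO4)c3)n[nH]c2c1` stands nearest to it, giving 121 nM, with a step of a 1.8-fold higher number from compound 1 to compound 3 (0.27 log units; within the scatter). Compound 2 `CCn1cc(-c2n[nH]c3cc(-c4cc(C(=O)Nc5cccc(C(F)(F)F)c5)ccc4C)ccc23)cn1` stands furthest, giving 257 nM, with a step of a 3.9-fold higher number from compound 1 to compound 2 (0.59 log units; beyond the scatter). Compound 4 `Cc1ccc(C(=O)Nc2cccc(C(F)(F)F)c2)cc1-c1ccc2c(-c3cnn(C4CCN(C)CC4)c3)n[nH]c2c1` differs from compound 1 in one place: 1-methylpiperidin-4-yl in place of methyl on an aromatic nitrogen. Both measured steps from compound 1 replace the methyl on the aromatic nitrogen with something larger, and the six-membered ring of compound 3 cost little. A modest rise is therefore expected, with a 1.7-fold higher number from compound 1 to compound 4 (0.22 log units; within the scatter) for compound 4. Compound 4 is estimated at 110 nM, within 40 nM to 350 nM.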

Compound 4, half-maximal inhibitory concentration: 93.3 nM
Beside the measured number, compound 4's estimate is 1.2-fold (0.07 log units) above it; the measured number falls inside the stated range.
By their numbers in this assay, from the lowest: compounds 1, 4 and 3 (each within the scatter of the next); then compound 2.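

In this assay a much larger group carrying a ring nitrogen is accepted on the aromatic nitrogen: a 1.4-fold higher number from compound 1 to compound 4 (0.15 log units; within the scatter) and a 1.3-fold lower number from compound 3 to compound 4 (0.11 log units; within the scatter) are both read as no real change. The gap to the ethyl group is larger, with a 2.8-fold lower number from compound 2 to compound 4 (0.44 log units; beyond the scatter), so among these compounds the number does not follow group size, and compound 2 goes against any such trend. No measured evidence accounts for this.

On these data alone, whether the ring nitrogen of compound 4 matters stays open. A cyclohexyl ring, or a longer chain ending in an amine, would test this.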